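Fluoro in place of hydrogen on the shared core

The source may report more compounds than this note shows. Statements on the series, on what has been measured and on what is new or still open speak of the compounds shown alone.

Within the data shown here, compound 1 `N/C(=N\NC(=S)N1CCCCCC1)c1ccccn1` has been tested in a functional assay on A-375 cells (Homo sapiens) for cytotoxicity, read by MTT assay, with a stated time of 72 h, tested at 100 uM (a lower number here means less inhibition of growth, a higher number more inhibition of growth at the concentration tested), where compound 1 gives 89%; the only other number known, from compound 2, lies within the scatter of it. Compound 2 `Cc1cccc(/C(N)=N/NC(=S)N2CCCCCC2)n1` gives 80.9% in this assay, and the step of a number 8.1 percentage points lower from compound 1 to compound 2 (within the scatter) corresponds to methyl in place of hydrogen on an aromatic carbon. Compound 3 `N/C(=N\NC(=S)N1CCCCCC1)c1ccc(F)cn1` has not yet been measured. It differs from compound 1 by fluoro in place of hydrogen on an aromatic carbon of the six-membered aromatic ring with one nitrogen, two atoms from the ring nitrogen and para to a large group. Among the measured compounds shown here, the one step that bears on this change, from compound 1 to compound 2, stayed within the scatter. For compound 3 the expected step is therefore a number 4 percentage points lower from compound 1 to compound 3 (within the scatter). Compound 3 is accordingly estimated at 85%, with a range from 70% to 96%.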

Compound 3, percent growth inhibition at one concentration: 85.7%
Beside the measured number, compound 3's estimate is 0.7 percentage points below it; the measured number falls inside the stated range.
By their numbers in this assay, from the lowest: compounds 2, 3 and 1 (each within the scatter of the next).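

In this assay, fluoro in place of hydrogen on an aromatic carbon gives a number 3.3 percentage points lower from compound 1 to compound 3 (within the scatter), so the read-out does not separate these two compounds. Among these compounds, this is the first reading for a change at this position, two atoms from the ring nitrogen and para to a large group, which the methyl step to compound 2 did not address, and it shows that the shared core can carry a fluoro here without a step beyond the scatter. No evidence is available that would explain this result.

The compounds shown leave open whether another group at this position, such as chloro, methoxy or an amine, would also stay within the scatter. They also leave open whether fluoro here would give a step beyond the scatter at a lower concentration.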